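This account rests on a few compounds, and the source may have more. Where it says the series, first, only, none or still open, it means among the compounds named here.

Among the measured compounds shown here, only two compounds have been tested so far, and both were tested in a functional assay on Bel-7402 cells (Homo sapiens) for inhibition, read by MTT assay, with a stated time of 24 h, tested at 10 ug/mL; a higher number here means more inhibition of growth at the concentration tested, a lower number less inhibition of growth. In this assay, compound 1 `O=C(CCCCC1CCSS1)Nc1ccccc1Cl` is recorded as "not active" (no number reported), with no number attached. For the measured compounds named here, compound 2 `O=C(CCCCC(S)CCS)Nc1ccccc1` gives 3.72%, the only number available, so it has no other number to be ranked against. The one other entry offers only that verbal result.

Compound 3 `O=C(CCCCC(S)CCS)Nc1ccccc1Cl` is compound 2 with a single change: chloro in place of hydrogen on an aromatic carbon. This places chloro in place of hydrogen on an aromatic carbon, ortho to a large group. Going by the values given here, no measured pair shows what such a swap does in this assay, so any forecast rests on very little. What the data do show is weak growth inhibition, with compound 2 at 3.72% and compound 1 at "not active" (no number reported). A low reading is therefore the natural expectation, and no shift beyond the usual scatter is anticipated. The estimated change is a number 3.3 percentage points higher from compound 2 to compound 3 (within the scatter), a small expected rise that stays within that scatter. For compound 3 the expected value is 7%, with an estimated range from 0% to 20%.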

Compound 3, percent growth inhibition at one concentration: "not active" (no number reported)
Nothing numeric was reported for compound 3, so the estimate cannot be set against anything.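

In this assay, among the compounds shown here, compound 3 gives "not active" (no number reported), so no step between compound 2 and compound 3 can be read. The compounds shown leave open whether chloro in place of hydrogen on an aromatic carbon changes growth inhibition at all. No measurement at hand bears on this result.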